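The compounds below may be only part of what the source reports. "The series", "measured", "known", "first", "only" and "open" are said of these compounds alone.

In a functional assay on A549 cells (Homo sapiens) for inhibition, read by MTT assay, with a stated time of 72 h (on this read-out higher numbers stand for weaker inhibition and lower numbers for stronger inhibition), the measured compounds are:
- Compound 1 `CNC(=O)CCCCCCCn1nc(-c2cnc3[nH]ccc3c2)c2c(N)ncnc21`: 51000 nM
- Compound 2 `Nc1nc2cc(-c3nn(CCCC(=O)NO)c4ncnc(N)c34)ccc2o1`: > 100000 nM (a limit of the assay, not a number)

Compound 2 has no number of its own in this assay, only the limit > 100000 nM. Compound 3 `Nc1nc2cc(-c3nn(CCCCCCCCC(=O)NO)c4ncnc(N)c34)ccc2o1` differs from compound 2 in one place: 5-(hydroxycarbamoyl)pentyl in place of hydroxycarbamoyl on a saturated chain carbon, three bonds along the chain from an aromatic nitrogen. Among the measured compounds shown here, no measured step shows what this change does. For the measured compounds named here, the only numerical value comes from compound 1 at 51000 nM, which also carries a longer chain than compound 2, although it has a different core and no hydroxycarbamoyl group. This is thin support, but a large move towards stronger inhibition, well beyond the scatter, is expected: an at least 25-fold lower number from compound 2 to compound 3 (1.39 log units; beyond the scatter). For compound 3 the expected value is 4000 nM, with an estimated range from 400 nM to 40000 nM.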

Compound 3, half-maximal inhibitory concentration: 13200 nM
Compound 3: the middle estimate sits 3.3-fold (0.52 log units) below what was measured; low and high end bracket the measured number.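

In this assay, putting 5-(hydroxycarbamoyl)pentyl in place of hydroxycarbamoyl on a saturated chain carbon, three bonds along the chain from an aromatic nitrogen, gives an at least 7.5-fold lower number from compound 2 to compound 3 (0.87 log units; beyond the scatter). Among the compounds shown here, this is the first measured step at this position, and it shows that on the shared core the read-out responds to lengthening the chain that ends in the hydroxycarbamoyl group, which compound 1, with its different core and no such group, could not show. The step has a floor but no exact size because compound 2 has only a limit, not a number: the limit of > 100000 nM in this assay, at which 1 of the 3 values shown sits.

The compounds shown leave open how the read-out changes with chains of intermediate length or with a longer chain than that of compound 3. They also leave open whether a carboxylic acid or a methyl amide at the chain end would serve in place of the hydroxycarbamoyl group on this core.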